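The compounds below may be only part of what the source reports. "The series", "measured", "known", "first", "only" and "open" are said of these compounds alone.

Measured compounds:
- compound 1, `COc1cc(Cl)cc(-c2nn(-c3cccc(NC(=O)Nc4ccc(Cl)c(C(F)(F)F)c4)c3)cc2-c2ccncc2)c1`, 63%
- compound 2, `COc1cc(Cl)cc(-c2nn(-c3cccc(NC(=O)Nc4cc(C(F)(F)F)cc(C(F)(F)F)c4)c3)cc2-c2ccncc2)c1`, 19%
- compound 3, `COc1cc(Cl)cc(-c2nn(-c3cccc(NC(=O)Nc4ccc(Cl)c(Cl)c4)c3)cc2-c2ccncc2)c1`, 93%

In a functional assay on SW-620 cells (Homo sapiens) for inhibition, read by sulforhodamine B assay, with a stated time of 48 h, tested at 1 uM (on this read-out higher numbers stand for a weaker effect at the one concentration tested and lower numbers for a stronger effect), compound 3 stands highest of the three numbers; its nearest neighbour is compound 1, lower by a step beyond the scatter, and compound 2 lies far below it. Among the measured compounds shown here, the one step among measured compounds that differs in a single place is a number 30 percentage points higher from compound 1 to compound 3 (beyond the scatter), a modest rise in the number.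

Compound 4, `COc1cc(Cl)cc(-c2nn(-c3cccc(NC(=O)Nc4cccc(C(F)(F)F)c4)c3)cc2-c2ccncc2)c1`, has not been measured. It differs from compound 3 by 3-(trifluoromethyl)phenyl in place of 3,4-dichlorophenyl on an amide-type nitrogen. For the measured compounds named here, this change moves the aryl group of compound 3 toward the trifluoromethyl-bearing pattern of compound 1 and compound 2, both of which gave lower numbers than compound 3, and the one comparable step, a number 30 percentage points higher from compound 1 to compound 3 (beyond the scatter), ran the opposite way. A lower number than that of compound 3 is therefore expected, of modest to moderate size, as a number 28 percentage points lower from compound 3 to compound 4 (beyond the scatter). Compound 4 is estimated at 65% in this assay, within 40% to 90%.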

Compound 4, a percentage reported as activity, at one concentration (the size of the read-out at that concentration, not a potency): 74%
The estimate for compound 4 lay 9 percentage points below the measured number; low and high end bracket the measured number.
By their numbers in this assay, from the lowest: compound 2; then compound 1; then compound 4; then compound 3.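

In this assay, the change on the amide-type nitrogen gives a number 19 percentage points lower from compound 3 to compound 4 (beyond the scatter), so a lone trifluoromethyl on the phenyl ring already has a stronger effect than the 3,4-dichlorophenyl group. The second substituent counts very differently in the two trifluoromethyl-bearing compounds: taking away the further trifluoromethyl gives a number 55 percentage points higher from compound 2 to compound 4 (beyond the scatter), whereas taking away the chloro gives only a number 11 percentage points higher from compound 1 to compound 4 (beyond the scatter). Nothing given here accounts for these differences.

The compounds shown leave open how a lone chloro, with no trifluoromethyl, would compare on this phenyl ring. They also leave open whether a methoxy group or a nitrile in place of the trifluoromethyl of compound 4 would keep its number in this assay.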